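Swapping Hydroxy for Amino on the Amide Chain

This account rests on a few compounds, and the source may have more. Where it says the series, first, only, none or still open, it means among the compounds named here.

Of the compounds shown here, two have been measured in a functional assay on A2780 cells (Homo sapiens) for antiproliferative activity, read by MTT assay, with a stated time of 48 h; a lower number here means a stronger inhibitor, a higher number a weaker inhibitor. Compound 1 `CNCC(=O)Nc1cc(OC)ccc1C(=O)c1ccc2c(c1)C=CC(C)(C)O2` gives 850 nM in this assay. Compound 2 `C=C(c1ccc(OC)cc1NC(=O)CO)c1ccc(OC)c2c1C=CC(C)(C)O2` gives 280 nM in this assay, the lowest of the two numbers, and the gap to compound 1 lies beyond the usual scatter. Compound 1 and compound 2 differ in more than one place, so their two values alone do not tell which part of the structure matters.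

Compound 3 `C=C(c1ccc(OC)cc1NC(=O)CN)c1ccc(OC)c2c1C=CC(C)(C)O2` has not been measured yet. It differs from compound 2 in a single place: amino in place of hydroxy on a saturated chain carbon bound to a carbonyl carbon. For the measured compounds named here, no measured pair shows this particular change, so there is no step of this kind to lean on. The step from compound 2 to compound 3 is therefore expected to be small, no larger than the scatter, and in no clear direction: a 1.1-fold lower number from compound 2 to compound 3 (0.05 log units; within the scatter). Compound 3 is estimated at 250 nM, within a range from 80 nM to 900 nM.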

Compound 3, half-maximal inhibitory concentration: 400 nM
The estimate for compound 3 lay 1.6-fold (0.20 log units) below the measured number, and the stated range covers the measured number.
By their numbers in this assay, from the lowest: compounds 2 and 3 (each within the scatter of the next); then compound 1.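

Putting amino in place of hydroxy on a saturated chain carbon bound to a carbonyl carbon gives a 1.4-fold higher number from compound 2 to compound 3 (0.15 log units; within the scatter) in this assay. For the compounds shown here, this is the first pair that differs only at this place, and it shows that, on this shared core, the two groups cannot be told apart by this read-out: the hydroxy is not needed to keep the number in the same range. No measurement shown here offers an explanation for this result.

As far as these compounds go, it remains open whether a dimethylamino group, a carboxylic acid or a longer chain at this place would also keep the number in that range. Also open is which of the several differences between compound 1 and compound 2 accounts for the gap between their values.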